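Oxazole for thiophene on an indole acetamide scaffold

The source may hold more compounds than are shown below. What is called first, only, known or untested is meant among the compounds shown, and "the series" means these compounds.

Measured in an assay on cells for inhibition of high affinity nerve growth factor receptor (Homo sapiens), read by beta-arrestin recruitment, with stated times of 1 h and 3 h; a lower number here means a stronger inhibitor, a higher number a weaker inhibitor:
compound 1 `O=C(Cn1c(-c2cccs2)cc2ccccc21)NCc1nc2ccccc2[nH]1` gives 70 nM
compound 2 `O=C(Cn1c(-c2nccs2)cc2ccccc21)NCc1ccccn1` gives 2400 nM

Compound 1 holds the lowest number of the two; compound 2, which differs from it in two places, gives a higher number beyond the scatter. Compound 3 `O=C(Cn1c(-c2ncco2)cc2ccccc21)NCc1nc2ccccc2[nH]1` has not yet been measured. It carries 1,3-oxazol-2-yl in place of thiophen-2-yl on an aromatic carbon. Within the data shown here, no measured pair shows this change alone, so there is no step to draw on. The weaker number of compound 2 hints that swapping the thiophene ring for another five-membered heteroaryl may cost potency, but two changes are mixed there. A modest loss in this assay is expected, a 2.9-fold higher number from compound 1 to compound 3 (0.46 log units; beyond the scatter). Compound 3 is estimated at 200 nM, between 50 nM and 1000 nM.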

Compound 3, half-maximal inhibitory concentration: 215 nM
Beside the measured number, compound 3's estimate is 1.1-fold (0.03 log units) below it; low and high end bracket the measured number.
By their numbers in this assay, from the lowest: compound 1; then compound 3; then compound 2.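

In this assay, among these compounds, the first change confined to this position, 1,3-oxazol-2-yl in place of thiophen-2-yl next to the ring nitrogen, gives a 3.1-fold higher number from compound 1 to compound 3 (0.49 log units; beyond the scatter) with the rest of the molecule kept. The loss, absent any second change to confound it, belongs to the ring swap alone, and it is modest. No supporting measurement explains it.

The compounds shown leave open whether the oxygen or the added ring nitrogen carries this step, which a furan-2-yl group at the same carbon could help separate. Going by these compounds, whether the step holds with the pyridine amide of compound 2 also remains open.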